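Removing one methoxy group from a pyrazole-linked chalcone

The compounds below may be only part of what the source reports. "The series", "measured", "known", "first", "only" and "open" are said of these compounds alone.

Measured compounds:
compound 1, `COc1cc(-c2cc(/C=C/C(=O)c3ccc(N)cc3)[nH]n2)cc(OC)c1OC`: 96%
compound 2, `COc1ccc(C(=O)/C=C/c2cc(-c3cc(OC)c(OC)c(OC)c3)n[nH]2)cc1OC`: 95%
compound 3, `COc1ccc(C(=O)/C=C/c2cc(-c3cc(OC)c(OC)c(OC)c3)n[nH]2)cc1`: 99%

Three compounds were measured in a functional assay on CCRF-CEM cells (Homo sapiens) for cytotoxicity, read by sulforhodamine B assay, with a stated time of 48 h, tested at 0.01 uM; a lower number here means a stronger effect, a higher number a weaker effect of the compound at the concentration tested. Compound 1 gives 96%, compound 2 gives 95% and compound 3 gives 99%. Every pairwise step among them is small: a number 1 percentage points lower from compound 1 to compound 2 (within the scatter), a number 3 percentage points higher from compound 1 to compound 3 (within the scatter) and a number 4 percentage points higher from compound 2 to compound 3 (within the scatter). All three numbers therefore sit close to one another, and none of the compounds can be singled out.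

Compound 1 and compound 2 differ in the group on the carbonyl carbon: 4-aminophenyl in place of 3,4-dimethoxyphenyl on a carbonyl carbon. Between compound 2 and compound 3 the change is hydrogen in place of methoxy on an aromatic carbon, and it made the step of a number 4 percentage points higher from compound 2 to compound 3 (within the scatter).

The unmeasured compound 4, `COc1ccc(-c2cc(/C=C/C(=O)c3ccc(N)cc3)[nH]n2)cc1OC`, differs from compound 1 by hydrogen in place of methoxy on an aromatic carbon. This is the same kind of change as that from compound 2 to compound 3, but the surroundings of the place are not identical: in compound 1 the carbon that loses the methoxy group is also meta to a methoxy group, which is not the case in compound 2.

Because the step of a number 4 percentage points higher from compound 2 to compound 3 (within the scatter) lay within the scatter, compound 4 is expected to stay close to compound 1, with an expected step of a number 2 percentage points higher from compound 1 to compound 4 (within the scatter). Compound 4 is estimated to give 98% in this assay, expected between 90% and 105%.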

Compound 4, a percentage reported as activity, at one concentration (the size of the read-out at that concentration, not a potency): 97%
The estimate for compound 4 lay 1 percentage points above the measured number, and the stated range covers the measured number.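

In this assay, hydrogen in place of methoxy on an aromatic carbon gave a number 1 percentage points higher from compound 1 to compound 4 (within the scatter), and set beside the earlier case, the change carries from one core to the other with no difference that can be told apart: the same change on two cores in this assay, a number 4 percentage points higher (within the scatter) from compound 2 to compound 3 and a number 1 percentage points higher (within the scatter) from compound 1 to compound 4, 3 percentage points apart, within the scatter of two such steps In this small series, then, both cores tolerate the loss of this methoxy group without a step that stands out, and the two pairs agree, even though the place on compound 1 and the place on compound 2 do not have identical surroundings. Within the data shown here, this does not show that the change is without consequence in general, since the agreement rests on only two pairs, and each was read at a single concentration, which gives the size of the read-out and not a potency, so any difference between the cores that this read-out does not reach would go unseen.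

The compounds shown leave open whether they would separate from one another at a higher concentration, where a difference between the two cores might or might not appear. They also leave open how a hydroxyl group, a chlorine atom or a longer alkoxy chain such as ethoxy would behave at this place on either core.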